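The compounds below may be only part of what the source reports. "The series", "measured", "known", "first", "only" and "open" are said of these compounds alone.

Measured so far in a functional assay on PC-3 cells (Homo sapiens) for inhibition (a lower number here means a stronger inhibitor, a higher number a weaker inhibitor), are these compounds:
- compound 1 `CCn1c(=O)/c(=C2\Sc3ccccc3N2C)s/c1=C\c1ccncc1Nc1ccccc1F` gives 360 nM
- compound 2 `CCn1c(=O)/c(=C2\Sc3ccccc3N2C)s/c1=C\c1ccncc1Nc1ccccc1C` gives 1200 nM
- compound 3 `CCn1c(=O)/c(=C2\Sc3ccc(OC)cc3N2C)s/c1=C\c1ccncc1Nc1ccccc1C` gives 370 nM

Compound 3 holds the second highest of these three numbers, yet its value (370 nM) lies within the usual scatter of compound 1 (360 nM). Against compound 2 the gap is real, with a 3.2-fold lower number from compound 2 to compound 3 (0.51 log units; beyond the scatter) on adding a methoxy group.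

Compound 4 `CCn1c(=O)/c(=C2\Sc3ccc(OC)cc3N2C)s/c1=C\c1ccncc1Nc1ccccc1Cl` has not yet been measured. It carries chloro in place of methyl on an aromatic carbon, at a place on a six-membered aromatic ring of carbon only, ortho to a large group.

Among the compounds with values here, no compound with chloro at this place has a value yet, so the closest evidence is a different swap at the same place. There, methyl in place of fluoro gave a 3.3-fold higher number from compound 1 to compound 2 (0.52 log units; beyond the scatter) in a modest step. Losing the methyl for another halogen therefore points, tentatively, toward a lower number. The methoxy step does not bear directly on the comparison, since compound 3 and compound 4 both carry that group. Within the data shown here, with only one such comparison, a smaller step than the fluoro-to-methyl one seems likely. Expected is a 1.5-fold lower number from compound 3 to compound 4 (0.19 log units; within the scatter) and possibly nothing beyond the scatter. For compound 4 the estimated value is 240 nM (expected range 100 nM to 600 nM).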

Compound 4, half-maximal inhibitory concentration: 760 nM
The estimate for compound 4 lay 3.2-fold (0.50 log units) below the measured number; the measured number lies above the stated range.
By their numbers in this assay, from the lowest: compounds 1 and 3 (each within the scatter of the next); then compounds 4 and 2 (each within the scatter of the next).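

In this assay, chloro in place of methyl on the aromatic carbon gives a 2.1-fold higher number from compound 3 to compound 4 (0.31 log units; beyond the scatter), a modest step showing that a halogen at this place does not automatically give a lower number than methyl. The earlier step at the same place, a 3.3-fold higher number from compound 1 to compound 2 (0.52 log units; beyond the scatter), made methyl the group with the higher number when set against fluoro, whereas here methyl is the group with the lower number when set against chloro, so fluoro and chloro do not behave as interchangeable halogens in these two pairs. This reading has a limit, as compound 3 and compound 4 carry a methoxy group that compound 1 and compound 2 lack, so the two steps were taken on different backgrounds, and no measurement at hand explains why they point in opposite directions.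

On these data alone, it remains open whether swapping methyl for chloro gives the same step without the methoxy group, and whether swapping methyl for fluoro gives the same step with it. As far as these compounds go, how this place would respond to a hydroxyl, a nitrile or an amine also remains open.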